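Swapping vinyl for difluoromethyl on a small ring

The source may report more compounds than this note shows. Statements on the series, on what has been measured and on what is new or still open speak of the compounds shown alone.

Compound 3, with the structure `C=C[C@@H]1C[C@]1(NC(=O)[C@@H]1[C@H](CC)[C@@H]2CN1C(=O)[C@H](C(C)(C)C)NC(=O)O[C@@H]1C[C@H]1CCCCCc1nc3ccc(OC)cc3nc1O2)C(=O)NS(=O)(=O)C1CC1`, is the most lipophilic of the three measured compounds: in a physicochemical assay for lipophilicity (a higher number here means a more lipophilic compound, a lower number a more polar compound), compound 3 gives 4.1. Its nearest neighbour is compound 2, `CC[C@@H]1[C@@H]2CN(C(=O)[C@H](C(C)(C)C)NC(=O)O[C@@H]3C[C@H]3CCCCCc3nc4ccc(OC)cc4nc3O2)[C@@H]1C(=O)N[C@]1(C(=O)NS(=O)(=O)C2(C)CC2)C[C@H]1C(F)F`, which in this assay gives 3.8, a number within the scatter of compound 3. Compound 1, `COc1ccc2nc3c(nc2c1)O[C@H]1CN(C(=O)[C@H](C(C)(C)C)NC(=O)O[C@@H]2C[C@H]2CCCCC3)[C@H](C(=O)N[C@]2(C(=O)NS(=O)(=O)C3(C)CC3)C[C@H]2C(F)F)[C@@H]1C`, stands furthest away and in this assay gives 3.5.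

Compound 4 is `CC[C@@H]1[C@@H]2CN(C(=O)[C@H](C(C)(C)C)NC(=O)O[C@@H]3C[C@H]3CCCCCc3nc4ccc(OC)cc4nc3O2)[C@@H]1C(=O)N[C@]1(C(=O)NS(=O)(=O)C2CC2)C[C@H]1C(F)F`. It differs from compound 3 in one place: difluoromethyl in place of vinyl on a saturated ring carbon.

For the measured compounds named here, the only measured step, a number 0.30 log units higher from compound 1 to compound 2 (within the scatter), adds a methyl group elsewhere in the molecule and does not bear on a vinyl-to-difluoromethyl exchange. Going by the values given here, no step on record speaks to this change directly, so the expectation leans on the small spread among the three measured numbers. Compound 4 is therefore expected to land close to compound 3, with a step of about a number 0.10 log units lower from compound 3 to compound 4 (within the scatter), which is within the scatter. The estimate for compound 4 in this assay is 4, expected to fall between 3.6 and 4.4.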

Compound 4, distribution coefficient: 3.5
Compound 4: middle estimate off by 0.50 log units, on the high side; measured number below the stated range.
By their numbers in this assay, from the lowest: compounds 1, 4, 2 and 3 (each within the scatter of the next, the first and the last beyond it).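

In this assay, for the compounds shown here, the exchange of vinyl for difluoromethyl on a saturated ring carbon of this three-membered ring gives the first direct reading for this change: a number 0.60 log units lower from compound 3 to compound 4 (beyond the scatter). The other new step, hydrogen in place of methyl on a saturated ring carbon, gives a number 0.30 log units lower from compound 2 to compound 4 (within the scatter), so in this small set the vinyl exchange moves the number further than removing that methyl does. Nothing shown gives a measured reason for the size of the vinyl-to-difluoromethyl step.

On these data alone, this change is seen in a single pair, so whether it gives a similar step on other versions of the shared core remains open. An ethyl or trifluoromethyl group on the same ring carbon lies outside the compounds shown, so where either would fall relative to vinyl and difluoromethyl is also open.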